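Nitro on the Benzoyl Ring of an Indole Enone

The compounds below may be only part of what the source reports. "The series", "measured", "known", "first", "only" and "open" are said of these compounds alone.

Measured so far:
Compound 1 `O=C(/C(=C\c1c(-c2ccccc2)[nH]c2ccccc12)C(=O)C(F)(F)F)c1ccco1`: 10000 nM
Compound 2 `CCOC(=O)/C(=C/c1c(-c2ccccc2)[nH]c2ccccc12)C(=O)c1ccccc1`: 43000 nM
Compound 3 `O=C(C(=Cc1c(-c2ccccc2)[nH]c2ccccc12)C(=O)c1ccccc1)c1ccccc1`: > 100000 nM (a limit)

In a functional assay on MCF7 cells (Homo sapiens) for cytotoxicity, read by MTT assay, with a stated time of 96 h (a higher number here means that more compound is needed for the effect, a lower number that less compound is needed), compound 1 gives 10000 nM. Compound 2 gives 43000 nM, the higher of the two numbers, and its gap to compound 1 lies beyond the scatter. For compound 3 the assay reports only a limit, > 100000 nM, namely (the limit of > 100000 nM in this assay, at which 1 of the 3 values shown sits).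

Compound 4 `CCOC(=O)/C(=C/c1c(-c2ccccc2)[nH]c2ccccc12)C(=O)c1ccc([N+](=O)[O-])cc1` differs from compound 2 by nitro in place of hydrogen on an aromatic carbon. Within the data shown here, no two measured compounds differ in one place, so no measured step guides the expectation. The step that the estimate implies, a 1.1-fold lower number from compound 2 to compound 4 (0.03 log units; within the scatter), is expected to be small, with no direction beyond the scatter. Compound 4 is therefore expected to give about 40000 nM, within a range from 12000 nM to 100000 nM.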

Compound 4, half-maximal effective concentration: 40000 nM
For compound 4 middle estimate and measured number coincide at the digits printed, within the range that was stated.
By their numbers in this assay, from the lowest: compound 1; then compounds 4 and 2 (each within the scatter of the next). At a limit, above all of these: compound 3.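

Phenyl to 4-nitrophenyl gives a 1.1-fold lower number from compound 2 to compound 4 (0.03 log units; within the scatter) in this assay, the first step in this series that changes one place only. It shows that nitro can stand on this aromatic carbon, para to a large group, without moving the number beyond the scatter. No measurement given here bears on why this is so.

On these data alone, whether an amine or a carboxylic acid on this same carbon would leave the number equally unmoved remains open. So does the outcome of nitro on another carbon of this ring.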